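The source may report more compounds than this note shows. Statements on the series, on what has been measured and on what is new or still open speak of the compounds shown alone.

Compound 3 `Cc1ccc2c(=O)c(CSC(=S)N3CCCC3)coc2c1` gives, in a functional assay on MCF7 cells (Homo sapiens) for antiproliferative activity, read by MTT assay, with a stated time of 72 h (on this read-out lower numbers stand for stronger inhibition and higher numbers for weaker inhibition), 41400 nM, the highest of the two numbers in this small set. Compound 1 `Cc1ccc2c(=O)c(CSC(=S)N3CCCCC3)coc2c1` gives 800 nM in this assay. Compound 2 `O=c1c(CSC(=S)N2CCCC2)coc2ccccc12` reaches only a limit of this assay, > 25000 nM. Among the measured compounds shown here, the step of a 52-fold higher number from compound 1 to compound 3 (1.71 log units; beyond the scatter) is the only measured step that touches the group on the thiocarbonyl carbon, and it is large; the step that the limit leaves unreadable from compound 2 to compound 3 cannot be sized because of the limit of > 25000 nM in this assay, at which 1 of the 3 values shown sits. Compound 4 `Cc1ccc2c(=O)c(CSC(=S)N(C(C)C)C(C)C)coc2c1` carries diisopropylamino in place of pyrrolidin-1-yl on a thiocarbonyl carbon. For the measured compounds named here, no measured step exchanges a ring for an open chain at this position, so neither the direction nor the size of the coming step can be read from compound 1 or compound 2; the one known change at this position was large, so a large step in either direction would not surprise. With that uncertainty, the step from compound 3 to compound 4 is estimated as a 4.1-fold lower number from compound 3 to compound 4 (0.62 log units; beyond the scatter). Compound 4 is expected to give 10000 nM in this assay, within 1500 nM to 50000 nM.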

Compound 4, half-maximal inhibitory concentration: 6600 nM
The estimate for compound 4 lay 1.5-fold (0.18 log units) above the measured number; the measured number falls inside the stated range.
By their numbers in this assay, from the lowest: compound 1; then compound 4; then compound 3.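

Among the compounds shown here, the first exchange of a ring for an open chain on the thiocarbonyl carbon gives a 6.3-fold lower number from compound 3 to compound 4 (0.80 log units; beyond the scatter) in this assay, so the pyrrolidin-1-yl group is not the better of these two groups here. Set against piperidin-1-yl, the same open chain gives an 8.3-fold higher number from compound 1 to compound 4 (0.92 log units; beyond the scatter) and so lies on the weaker side of that ring. A ring at this position is therefore neither better nor worse than the open chain as such, since one ring falls on each side of diisopropylamino. Nothing in the data shown accounts for these differences.

Still open is where a morpholin-4-yl or diethylamino group on this carbon would fall among these three groups. For the compounds shown here, the contribution of the methyl on the shared core also stays open: the only step that touches it cannot be read.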